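A few compounds are considered here, and "the series" means these few. Any claim that something is new, unique, unknown or untested is made for them only; others in the source may bear on it.

In a functional assay on SK-OV-3 cells (Homo sapiens) for antiproliferative activity, read by sulforhodamine B assay, with a stated time of 72 h (a lower number here means a stronger inhibitor, a higher number a weaker inhibitor), the measured compounds are:

compound 1 `O=C1CS/C(=N/Nc2nncc3ccccc23)N1c1ccccc1` with 7.9 nM
compound 2 `Cc1cc(C)nc(NS(=O)(=O)c2ccc(Nc3nncc4ccccc34)cc2)n1` with 0.08 nM
compound 3 `Clc1ccc(C(/C=C/c2ccccc2)=N\Nc2nncc3ccccc23)cc1` with 0.07 nM

Compound 1 has the highest number of the three, which makes it the weakest inhibitor here, and its gaps to both others lie beyond the scatter. Compound 4 `O=C1CS/C(=N/Nc2nncc3ccccc23)N1` differs from it by one change, hydrogen in place of phenyl on an amide-type nitrogen in a ring and nothing else. For the measured compounds named here, no measured pair isolates this change, so the data give no direct size for it. Compound 1 with 7.9 nM carries a carbon-only aromatic ring outside the shared core, as do compound 2 and compound 3, whereas compound 4 would have none. On this thin basis, a step in this assay towards a higher number is expected, modestly beyond the scatter. The estimated change is a 3.2-fold higher number from compound 1 to compound 4 (0.50 log units; beyond the scatter) in that direction. The estimate for compound 4 is 25 nM with an expected range of 4 nM to 150 nM for now.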

Compound 4, half-maximal inhibitory concentration: 0.8 nM
Estimate against measurement, compound 4: 31-fold (1.49 log units) above, and the stated range ends above it.
By their numbers in this assay, from the lowest: compounds 3 and 2 (each within the scatter of the next); then compound 4; then compound 1.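

In this assay, the step from phenyl to hydrogen on the amide-type nitrogen in the ring gives a 9.9-fold lower number from compound 1 to compound 4 (0.99 log units; beyond the scatter), and a lower number here means a stronger inhibitor. For the compounds shown here, this is the first pair that isolates this position, and it shows that the phenyl is not needed for strong antiproliferative activity in these cells: the compound without it is the stronger inhibitor of the two. Nothing available explains why removing the phenyl strengthens inhibition.

With only phenyl and hydrogen shown at this nitrogen, it remains open how a small group such as methyl, a longer chain or a chain ending in an amine or a carboxylic acid would compare. From the compounds shown here alone, it is also open whether the same change would have a similar effect on another core.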